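Small ring swap on a urea series: exposure ahead

This account rests on a few compounds, and the source may have more. Where it says the series, first, only, none or still open, it means among the compounds named here.

Compound 1 `CN1CCN(CCCS(=O)(=O)c2ccc3nc(NC(=O)NC(=O)c4cc(-n5cccn5)c(Cl)cc4Cl)sc3c2)CC1`: 30 nM
Compound 2 `CCc1ccc(Cl)c(C(=O)NC(=O)Nc2nc3ccc(S(=O)(=O)CCCN4CCN(C)CC4)cc3s2)c1`: 1500 nM
Compound 3 `Cc1cc(C)n(-c2ccc(Cl)c(C(=O)NC(=O)Nc3nc4ccc(S(=O)(=O)CCCN5CCN(C)CC5)cc4s3)c2)n1`: 78 nM

All three values come from an ADME assay on the whole organism (strain Han-Wistar) for pharmacokinetics, with Rattus norvegicus as the target, read by LC-MS, at a dose of 2 mg/kg by the oral route; on this read-out lower numbers stand for lower exposure and higher numbers for higher exposure at the dose given. Compound 3 stands second highest of the three numbers, above compound 1 and far under compound 2. Compound 4 `CN1CCN(CCCS(=O)(=O)c2ccc3nc(NC(=O)NC(=O)c4cc(N5CCCC5)ccc4Cl)sc3c2)CC1` has not been measured yet. It carries pyrrolidin-1-yl in place of 3,5-dimethyl-1H-pyrazol-1-yl on an aromatic carbon. Within the data shown here, the one measured step at this place, a 19-fold lower number from compound 2 to compound 3 (1.28 log units; beyond the scatter), was large, and it brought in the group that now leaves. Going by these compounds, removing that group may undo part of this drop, so a moderate rise in this assay is expected, though the new ring is untested here. The expected size is a 2.6-fold higher number from compound 3 to compound 4 (0.41 log units; beyond the scatter). The estimate for compound 4 is 200 nM, with an expected range from 40 nM to 1000 nM.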

Compound 4, maximal plasma concentration: 640 nM
Beside the measured number, compound 4's estimate is 3.2-fold (0.51 log units) below it; the range from low to high includes it.
By their numbers in this assay, from the lowest: compound 1; then compound 3; then compound 4; then compound 2.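

Swapping the aromatic pyrazole for the non-aromatic pyrrolidin-1-yl gives an 8.2-fold higher number from compound 3 to compound 4 (0.91 log units; beyond the scatter) in this assay, so a ring at this place does not by itself bring low exposure, and the kind of ring matters. Ethyl still leads, with a 2.3-fold lower number from compound 2 to compound 4 (0.37 log units; beyond the scatter), but the gap is far smaller than the one left by the dimethylpyrazole. No measurement here explains why the two rings differ. Going by these compounds, it remains open whether a morpholine ring or a simple dimethylamino group at this place would match or pass compound 2.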